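Replacing the phenethyl tail of compound 1 with cyclohexyl

This account rests on a few compounds, and the source may have more. Where it says the series, first, only, none or still open, it means among the compounds named here.

Working notes on a small set of acylguanidines carrying an aminothiazole head group. For the measured compounds named here, compound 1, `Cc1nc(N)sc1CCCN/C(N)=N/C(=O)NCC(C)CCc1ccccc1`, is the stronger of the two measured members. In a functional assay on HEK293T cells for agonist activity at histamine H2 receptor (Homo sapiens), read by beta-arrestin recruitment (a higher number here means that more compound is needed for the effect, a lower number that less compound is needed), compound 1 gives 355 nM. Compound 2, `N/C(=N\C(=O)NCc1ccccc1)NC1CCc2nc(N)sc2C1`, carries the aminothiazole fused into a ring and a benzyl group on the urea nitrogen; in this assay compound 2 gives 4370 nM. Going by the values given here, the gap between these two values is beyond the scatter, so compound 1 stands as the lower of the two numbers, though the two compounds differ in more than one place and no single step between them can be isolated.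

Compound 3, `Cc1nc(N)sc1CCCN/C(N)=N/C(=O)NCC(C)C1CCCCC1`, is the next variation: cyclohexyl in place of phenethyl on a saturated chain carbon bound to two saturated chain carbons. Among the compounds with values here, no measured pair shows this change. The expectation is a small step from compound 1 to compound 3 of a 1.7-fold higher number from compound 1 to compound 3 (0.23 log units; within the scatter), towards a somewhat higher number, within or only slightly beyond the scatter. For compound 3 in this assay the estimated value is 600 nM, with a range from 180 nM to 2000 nM.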

Compound 3, half-maximal effective concentration: 224 nM
Beside the measured number, compound 3's estimate is 2.7-fold (0.43 log units) above it; measured number inside the range.
By their numbers in this assay, from the lowest: compounds 3 and 1 (each within the scatter of the next); then compound 2.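

For the compounds shown here, this is the first step that differs in one place: in this assay, cyclohexyl in place of phenethyl on a saturated chain carbon bound to two saturated chain carbons gives a 1.6-fold lower number from compound 1 to compound 3 (0.20 log units; within the scatter). The position therefore accepts a non-aromatic ring of carbon only in place of an aromatic one, and a group of 6 heavy atoms in place of one of 8, with the read-out staying within the scatter; on this single pair, an aromatic ring in the tail is not required for a number in this range. Nothing available explains why the two tails read alike.

From the compounds shown here alone, the tails compared here are all-carbon groups with no hydrogen-bond donors or acceptors, so it remains open whether an amine, a carboxylic acid or a longer alkyl chain in the same place would stay within the scatter of compound 1 and compound 3. Also open, going by these compounds, is whether cyclohexyl in place of the benzyl group of compound 2, on its fused core, would give a step of similar size.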